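Swapping Fluoro for Vinyl on a Weakly Cytotoxic Amide

The source may report more compounds than this note shows. Statements on the series, on what has been measured and on what is new or still open speak of the compounds shown alone.

Of the compounds shown here, two have so far been tested in a functional assay on BGC-823 cells (Homo sapiens) for cytotoxicity, read by CCK-8 assay, with a stated time of 24 h; on this read-out higher numbers stand for weaker inhibition and lower numbers for stronger inhibition. Compound 1 `C/C(=C\c1ccc(-c2ccc(C)cc2)o1)C(N)=O` carries a methyl-substituted phenyl on its core. In this assay compound 1 gives > 50000 nM, which is a limit of the assay rather than a measured number. Compound 2 `C/C(=C\c1cc(-c2ccc(F)cc2)cs1)C(N)=O` carries a fluoro-substituted phenyl instead. In this assay compound 2 gives > 50000 nM, again a limit of the assay. Both results therefore sit at the same point, namely (the limit of > 50000 nM in this assay, at which 2 of the 2 values shown sit), so compound 2 stands nowhere distinct among the numbers shown. Compound 3 `C=Cc1ccc(-c2csc(/C=C(\C)C(N)=O)c2)cc1` has not yet been measured; it differs from compound 2 by vinyl in place of fluoro on an aromatic carbon, in words vinyl in place of fluoro on an aromatic carbon. Going by the values given here, no step between measured compounds exists to lean on, so the expected step from compound 2 to compound 3 is a number no higher from compound 2 to compound 3 (the limit leaves the size open), that is, none beyond the scatter. Compound 3 is expected to give about 50000 nM, within a range from 15000 nM to 150000 nM.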

Compound 3, half-maximal inhibitory concentration: > 50000 nM
Compound 3: only a limit was reported; the forecaster's own chance of this, stated with the estimate: 75%; the middle value lies on the limit itself.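

In this assay compound 3 gives > 50000 nM, which is a limit of the assay and not a number. Compound 2 also sits at a limit, so no step can be read between compound 2 and compound 3. The compounds shown leave open whether vinyl in place of fluoro changes cytotoxicity at all.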